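This account rests on a few compounds, and the source may have more. Where it says the series, first, only, none or still open, it means among the compounds named here.

Measured compounds:
- Compound 1, `Fc1ccc(-c2cn([C@@H]3CN4CCC3CC4)nn2)cc1`: in an assay on HEK293 cells for displacement of a labelled ligand from Neuronal acetylcholine receptor; alpha3/beta4 (Homo sapiens), read by scintillation counting, with a stated time of 120 min (a higher number here means a weaker inhibitor, a lower number a stronger inhibitor), compound 1 gives 3.09 nM
- Compound 2, `Oc1ccc(-c2cn([C@H]3CN4CCC3CC4)nn2)cc1`: in this assay compound 2 gives 138 nM

Within the data shown here, of the two numbers known in this assay, compound 2 has the higher one, so it is the weaker binder of the pair, and its gap to compound 1 lies well beyond the usual scatter of repeated measurements.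

Compound 3, `Fc1ccc(-c2cn([C@H]3CN4CCC3CC4)nn2)cc1`, has not yet been measured. It differs from compound 2 in one place: fluoro in place of hydroxy on an aromatic carbon, that is, a fluoro in place of a hydroxy on an aromatic carbon. Compound 3 is also the mirror image of compound 1, which carries the same fluoro; whether that matters for binding is not known from the two values at hand.

Among the measured compounds shown here, with no measured step that isolates this change, the expectation rests on the two compounds known. Since the fluoro compound 1 binds far more tightly than the hydroxy compound 2, compound 3 is expected to gain potency, with a step from compound 2 of a 9.2-fold lower number from compound 2 to compound 3 (0.96 log units; beyond the scatter).

Compound 3 is therefore estimated at 15 nM, within a range of 3 nM to 70 nM.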

Compound 3, inhibition constant: 1010 nM
Compound 3: middle estimate off by 67-fold (1.83 log units), on the low side, and the stated range ends below it.
By their numbers in this assay, from the lowest: compound 1; then compound 2; then compound 3.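

At this aromatic position, with the configuration held as drawn in compounds 2 and 3, replacing hydroxy with fluoro weakens binding, giving a 7.3-fold higher number from compound 2 to compound 3 (0.86 log units; beyond the scatter). Fluoro therefore brings no gain of its own here, and the tight binding of compound 1 cannot be credited to that group alone. The same fluoro appears on both sides of the much larger step a 330-fold higher number from compound 1 to compound 3 (2.51 log units; beyond the scatter), so the change at the saturated ring carbon, drawn S in compound 1 and R in compound 3, matters more in this pair than the aromatic swap does in the other, though one caveat applies to how this pair is read: the fact that one of compounds 1 and 3 is drawn with a defined configuration and the other without, at the place where they differ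

On these data alone, the hydroxy-to-fluoro step is known for only one configuration, so it remains open whether hydroxy would also outperform fluoro on the configuration of compound 1. Also unresolved is how a methoxy group or an amine at this same place, para to a large group, would compare with hydroxy and fluoro, which would show whether the oxygen or the hydrogen of the hydroxy is what counts.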